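A few compounds are considered here, and "the series" means these few. Any claim that something is new, unique, unknown or untested is made for them only; others in the source may bear on it.

Measured so far in a functional assay on the whole organism for inhibition, with Rattus norvegicus as the target, read by paw edema, at a dose of 100 mg/kg by the oral route; on this read-out lower numbers stand for less inhibition and higher numbers for more inhibition at the one dose given (going by the name of the read-out):
compound 1 `CCCCNC(=O)c1c(O)c2cccnc2n(-c2ccccc2)c1=O` gives 12.8%
compound 2 `O=C(NN1CCOCC1)c1c(O)c2cccnc2n(-c2ccccc2)c1=O` gives -8.5%
compound 3 `COc1cccc(NC(=O)c2c(O)c3cccnc3n(-c3ccccc3)c2=O)c1` gives 5.7%

Compound 3 sits second highest of the three numbers. Its nearest neighbour is compound 1, and the step of a number 7.1 percentage points lower from compound 1 to compound 3 (within the scatter) stays within the scatter, so no order between these two can be read. Compound 2 lies furthest off; the step of a number 14.2 percentage points higher from compound 2 to compound 3 (beyond the scatter) is modest but beyond the scatter.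

Compound 4 `O=C(Nc1cccc([N+](=O)[O-])c1)c1c(O)c2cccnc2n(-c2ccccc2)c1=O` differs from compound 3 in one place: nitro in place of methoxy on an aromatic carbon. Among the measured compounds shown here, none of the measured steps touches a substituent on the aromatic ring of the amide side chain; each of them exchanges the whole group on the amide-type nitrogen, namely a number 21.3 percentage points lower from compound 1 to compound 2 (beyond the scatter), a number 7.1 percentage points lower from compound 1 to compound 3 (within the scatter) and a number 14.2 percentage points higher from compound 2 to compound 3 (beyond the scatter). A direct precedent for nitro in place of methoxy on an aromatic carbon is therefore missing, and the one aryl-bearing amide measured, compound 3, stands close to the alkyl amide compound 1. On this basis no step beyond the scatter is expected in this assay for compound 4. For compound 4 the estimate is 5% (range -9% to 19%), an expected step of a number 0.7 percentage points lower from compound 3 to compound 4 (within the scatter).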

Compound 4, a percentage reported as inhibition, in the whole organism at one dose (the size of the read-out at that dose, not a potency): 5.7%
Compound 4: middle estimate off by 0.7 percentage points, on the low side, within the range that was stated.
By their numbers in this assay, from the lowest: compound 2; then compounds 3, 4 and 1 (each within the scatter of the next).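

In this assay, among the compounds shown here, the exchange of nitro for methoxy gives the first direct reading for a substituent on this aromatic carbon, meta to a large group: no change at the digits printed from compound 3 to compound 4 (within the scatter). Both aryl amides relate alike to the other two compounds: a number 14.2 percentage points higher from compound 2 to compound 4 (beyond the scatter), and a number 7.1 percentage points lower from compound 1 to compound 4 (within the scatter), so this change alters neither reading against the scatter. No measurement is available that bears on why methoxy and nitro give the same reading here.

From the compounds shown here alone, whether an amine or a carboxylic acid on this same aromatic carbon would leave the reading unchanged remains open, as does the effect of a chain longer than butyl on the amide nitrogen. Also open, going by these compounds, is whether any compound of this series would rise beyond the scatter above compound 1 at the one dose given.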